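Chloro on the benzoyl ring: one step from compound 3

This account rests on a few compounds, and the source may have more. Where it says the series, first, only, none or still open, it means among the compounds named here.

Measured compounds:
Compound 1 `CC1(C)S[C@@H]2/C(=C\C(=O)c3cc(C(F)(F)F)cc(C(F)(F)F)c3)C(=O)N2[C@H]1C(=O)OC(c1ccccc1)c1ccccc1` gives 39200 nM in a functional assay on A-375 cells (Homo sapiens) for cytotoxicity, read by MTT assay, with a stated time of 48 h; on this read-out higher numbers stand for weaker inhibition and lower numbers for stronger inhibition.
Compound 2 `CC1(C)S[C@@H]2/C(=C\C(=O)c3cc(F)cc(F)c3)C(=O)N2[C@H]1C(=O)OC(c1ccccc1)c1ccccc1` gives 19100 nM in this assay.
Compound 3 `CC1(C)S[C@@H]2/C(=C\C(=O)c3ccccc3)C(=O)N2[C@H]1C(=O)OC(c1ccccc1)c1ccccc1` gives 22800 nM in this assay.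

Compound 3 stands second highest of the three numbers; compound 2 is its nearest neighbour and compound 1 its furthest, and both gaps lie within the scatter. Among the measured compounds shown here, the only single-place step measured so far, a 1.2-fold higher number from compound 2 to compound 3 (0.08 log units; within the scatter), is also within the scatter. Compound 4 `CC1(C)S[C@@H]2/C(=C\C(=O)c3ccc(Cl)cc3)C(=O)N2[C@H]1C(=O)OC(c1ccccc1)c1ccccc1` differs from compound 3 by chloro in place of hydrogen on an aromatic carbon. For the measured compounds named here, the one measured step touches the same aromatic ring and was within the scatter, so no step beyond the scatter is expected in this assay for this change either. Compound 4 is therefore estimated at 22000 nM, with a range of 10000 nM to 50000 nM, which means an expected step of a 1.0-fold lower number from compound 3 to compound 4 (0.02 log units; within the scatter).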

Compound 4, half-maximal inhibitory concentration: 48600 nM
Compound 4: middle estimate off by 2.2-fold (0.34 log units), on the low side; the range from low to high includes it.
By their numbers in this assay, from the lowest: compounds 2, 3, 1 and 4 (each within the scatter of the next, the first and the last beyond it).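

In this assay, among the compounds shown here, the ring carbon para to a large group responds to substitution: chloro in place of hydrogen gives a 2.1-fold higher number from compound 3 to compound 4 (0.33 log units; beyond the scatter) and is the first single-place change on this ring to fall beyond the scatter. The exchange of 3,5-difluorophenyl for 4-chlorophenyl likewise gives a 2.5-fold higher number from compound 2 to compound 4 (0.41 log units; beyond the scatter) and points the same way, towards weaker inhibition. No measurement available here explains this step.

Open, on these data alone, is whether the step is particular to chloro or also appears with methoxy or an amine at this carbon. Also open, as far as these compounds go, is whether chloro on another ring carbon gives a comparable step.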